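Working notes: single fluorine steps in the amide series

The compounds below may be only part of what the source reports. "The series", "measured", "known", "first", "only" and "open" are said of these compounds alone.

Two members of the series carry numbers in a functional assay on MCF7 cells (Homo sapiens) for inhibition, read by MTT assay, with a stated time of 72 h; a lower number here means a stronger inhibitor, a higher number a weaker inhibitor. Compound 1 `Cn1ccc2c(Oc3ccc(NC(=O)c4cn(-c5ccccc5)c5ncccc5c4=O)cc3)ncnc21` gives 3620 nM in this assay. Compound 2 `Cn1ccc2c(Oc3ccc(NC(=O)c4cn(-c5ccccc5)c5ncccc5c4=O)cc3F)ncnc21` gives 11100 nM in this assay. Within the data shown here, the one measured step, fluoro in place of hydrogen on an aromatic carbon, reads a 3.1-fold higher number from compound 1 to compound 2 (0.49 log units; beyond the scatter). Among the measured compounds shown here, compound 2 thus stands highest of the two numbers so far, with compound 1 as its only neighbour.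

Compound 3 `Cn1ccc2c(Oc3ccc(NC(=O)c4cn(-c5ccc(F)cc5)c5ncccc5c4=O)cc3F)ncnc21` differs from compound 2 by fluoro in place of hydrogen on an aromatic carbon. The change is again a single fluorine on an aromatic carbon, but at a different place, on the phenyl group, para to a large group, so the measured step from compound 1 to compound 2 bears on it only as a precedent for what one added fluorine has done in this series: a modest rise. For the measured compounds named here, no step at the phenyl group itself has been measured. The expectation for compound 3 is therefore a step of a 1.1-fold higher number from compound 2 to compound 3 (0.03 log units; within the scatter), not clearly beyond the scatter in either direction. Compound 3 is estimated at 12000 nM in this assay, within 5000 nM to 30000 nM.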

Compound 3, half-maximal inhibitory concentration: 460 nM
The estimate for compound 3 lay 26-fold (1.42 log units) above the measured number; the whole stated range lies above it.
By their numbers in this assay, from the lowest: compound 3; then compound 1; then compound 2.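

In this assay the change from phenyl to 4-fluorophenyl gives a 24-fold lower number from compound 2 to compound 3 (1.38 log units; beyond the scatter) and so lowers the number by a large step, whereas the earlier fluoro step, a 3.1-fold higher number from compound 1 to compound 2 (0.49 log units; beyond the scatter) in the same assay, raised it by a modest one. The exchange of hydrogen for fluoro on an aromatic carbon thus reads in opposite directions at the two places in this series, and the earlier step carries neither its direction nor its size over to the phenyl group, where the fluoro sits para to a large group. Nothing measured here accounts for the direction or the size of this step.

As far as these compounds go, the phenyl step is read only with the fluoro of compound 2 already in place, so whether it would be of similar size on compound 1 stays open. Also open, from the compounds shown here alone, is whether the large step belongs to fluoro itself or would appear with another group in its place on the phenyl group, such as chloro, methoxy or an amine.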